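A few compounds are considered here, and "the series" means these few. Any claim that something is new, unique, unknown or untested is made for them only; others in the source may bear on it.

In a physicochemical assay for solubility, read by HPLC, measured as thermodynamic solubility, with a stated time of 4 h, at pH 6.8 (on this read-out lower numbers stand for lower solubility and higher numbers for higher solubility), compound 1 `Cn1c(COc2cccc(C(=O)O)c2)nc2ccc(Oc3ccc(Cl)c(F)c3)nc21` gives 1.7 ug/mL. Among the measured compounds shown here, compound 2 `Cc1cc(C)cc(Oc2ccc3nc(COc4cccc(C(=O)O)c4)n(C)c3n2)c1` gives 0.5 ug/mL, the lower of the two numbers so far. Compound 3 `Cn1c(COc2cccc(C(=O)O)c2)nc2ccc(Oc3ccc4c(c3)CCC4)nc21` differs from compound 2 in one place: 2,3-dihydro-1H-inden-5-yl in place of 3,5-dimethylphenyl on an oxygen on an aromatic ring. For the measured compounds named here, only one measured step bears on this, also on an oxygen on an aromatic ring: a 3.4-fold lower number from compound 1 to compound 2 (0.53 log units; beyond the scatter). That modest step removed 4-chloro-3-fluorophenyl, whereas the groups exchanged now both contain carbon only, so a smaller change seems likely. The expected step is a 1.2-fold higher number from compound 2 to compound 3 (0.08 log units; within the scatter), which would not clearly exceed the scatter. For compound 3 the estimated value is 0.6 ug/mL, with an expected range of 0.2 ug/mL to 1.6 ug/mL.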

Compound 3, solubility: 4.3 ug/mL
Compound 3: middle estimate off by 7.2-fold (0.86 log units), on the low side, outside the stated range (above it).
By their numbers in this assay, from the lowest: compound 2; then compound 1; then compound 3.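

In this assay, an exchange between two groups containing only carbon can still produce a clear shift at this position: 2,3-dihydro-1H-inden-5-yl in place of 3,5-dimethylphenyl gives an 8.6-fold higher number from compound 2 to compound 3 (0.93 log units; beyond the scatter). The same group in place of 4-chloro-3-fluorophenyl gives a 2.5-fold higher number from compound 1 to compound 3 (0.40 log units; beyond the scatter), so among these three compounds the highest number belongs to a group without chlorine or fluorine. Nothing measured here accounts for these differences. Still open, going by these compounds, is whether the five-membered non-aromatic ring itself goes with the higher number, and how an amine or a longer chain on this oxygen would read.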